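Swapping the Amide Cap of a Cell-Growth Inhibitor

A few compounds are considered here, and "the series" means these few. Any claim that something is new, unique, unknown or untested is made for them only; others in the source may bear on it.

Of the compounds shown here, two have been tested in a functional assay on HCT-116 cells (Homo sapiens) for inhibition, read by colorimetric assay, with a stated time of 3 days; on this read-out higher numbers stand for weaker inhibition and lower numbers for stronger inhibition. Compound 1 `COc1ccc(-c2cnc(NC(=O)CCCCCCNC(=O)C(O)(O)C(F)(F)F)s2)cc1` gives 930 nM. Compound 2 `O=C(CCCCCCNC(=O)C(O)(O)C(F)(F)F)Nc1ccncc1` gives 6670 nM, the higher of the two numbers; its gap to compound 1 lies beyond the usual scatter, so compound 2 is the weaker inhibitor of the pair. Compound 3 `O=C(CCCCCCNC(=O)C(O)(O)C(F)(F)F)Nc1cccc(Br)c1` has not yet been measured. It differs from compound 2 in one place: 3-bromophenyl in place of pyridin-4-yl on an amide-type nitrogen. The rest of the molecule, the long chain and its far end, is unchanged. For the measured compounds named here, no measured pair shows this exact change, so the direction can only be judged from compound 1, whose value 930 nM shows that a different group on the same chain can lower the number markedly. The step expected a 2.2-fold lower number from compound 2 to compound 3 (0.35 log units; beyond the scatter) is a modest move toward stronger inhibition, staying between the two known values. Compound 3 is expected to give 3000 nM, with a likely range from 1000 nM to 10000 nM.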

Compound 3, half-maximal inhibitory concentration: 3060 nM
Compound 3: middle estimate off by 1.0-fold (0.01 log units), on the low side; the range from low to high includes it.
By their numbers in this assay, from the lowest: compound 1; then compound 3; then compound 2.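

In this assay the swap of pyridin-4-yl for 3-bromophenyl on the amide-type nitrogen gives a 2.2-fold lower number from compound 2 to compound 3 (0.34 log units; beyond the scatter) and thus a modest move toward stronger inhibition. For the compounds shown here, this is the only one-place comparison at this position so far, and it shows that the group on this nitrogen can change the result while the long chain and its far end stay the same. Nothing at hand accounts for this shift.

The swap removes the ring nitrogen and adds a bromine in a single step, and the compounds shown cannot separate these two changes. A plain phenyl group on the same nitrogen would show how much of the step goes with the bromine and how much with the loss of the ring nitrogen.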